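The source may hold more compounds than are shown below. What is called first, only, known or untested is meant among the compounds shown, and "the series" means these compounds.

Three members of the series have a reading so far. Compound 1 `COc1ccc(CSc2nc(O)c(C)c(Cc3ccc(F)cc3)n2)cc1` gives 8900 nM in a functional assay on MT4 cells (Homo sapiens) for cytotoxicity, read by MTT assay; on this read-out higher numbers stand for lower toxicity in this test and lower numbers for higher toxicity in this test. Compound 3 `COc1ccc(CSc2nc(O)c(C)c(Cc3c(Cl)cccc3Cl)n2)c(OC)c1` is recorded in this assay only as a limit of the assay, > 55000 nM. Compound 2 `Cc1c(O)nc(SCc2ccc([N+](=O)[O-])cc2)nc1Cc1c(Cl)cccc1Cl` likewise gives no number in this assay but a limit, > 58000 nM. Thus compound 2 stands at one of the two limits among the three values, beside the limit of > 58000 nM in this assay, at which 1 of the 3 values shown sits, and (the limit of > 55000 nM in this assay, at which 1 of the 3 values shown sits).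

Compound 4 `Cc1c(O)nc(SCc2ccc(C#N)cc2)nc1Cc1c(Cl)cccc1Cl` differs from compound 2 by cyano in place of nitro on an aromatic carbon. Within the data shown here, no measured pair shows this change, so the step is unmeasured. The expected step in this assay is a step that the limit leaves unreadable from compound 2 to compound 4, within the usual scatter. Compound 4 is therefore estimated at 60000 nM, in a range from 20000 nM to 200000 nM, and most likely again only a limit.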

Compound 4, half-maximal cytotoxic concentration: > 60000 nM
Compound 4 ended at the assay's limit; the forecaster's own chance of this, stated with the estimate: 70%; the middle value sits exactly at the limit.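

In this assay compound 2 is only a limit, > 58000 nM. Compound 4 is likewise only a limit, > 60000 nM, so no step can be read between compound 2 and compound 4. The compounds shown leave open whether cyano in place of nitro changes the reading at all.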